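Removing the Side Chain from Compound 3

The compounds below may be only part of what the source reports. "The series", "measured", "known", "first", "only" and "open" are said of these compounds alone.

In a functional assay on A-431 cells (Homo sapiens) for antiproliferative activity, read by MTT assay, with a stated time of 72 h (a higher number here means a weaker inhibitor, a lower number a stronger inhibitor), compound 3 `O=C(Nc1cccc(CN2CCCC2)c1)Nc1ccc2ncnc(Nc3cccc(C(F)(F)F)c3)c2c1` gives 1230 nM, the lowest of the three numbers at hand. Compound 2 `O=C(Nc1cccc(CN2CCCCC2)c1)Nc1ccc2ncnc(Nc3cccc(C(F)(F)F)c3)c2c1` gives 1330 nM and compound 1 `CCN(CC)Cc1ccc(NC(=O)Nc2ccc3ncnc(Nc4cccc(C(F)(F)F)c4)c3c2)cc1` gives 3980 nM. Among the compounds with values here, of the two measured steps, a 3.2-fold lower number from compound 1 to compound 3 (0.51 log units; beyond the scatter) is the only change of clear size, whereas a 1.1-fold lower number from compound 2 to compound 3 (0.03 log units; within the scatter) lies within the scatter. Compound 4 `O=C(Nc1ccccc1)Nc1ccc2ncnc(Nc3cccc(C(F)(F)F)c3)c2c1` differs from compound 3 by hydrogen in place of (pyrrolidin-1-yl)methyl on an aromatic carbon. Neither measured step bears on this change directly: one moves and reshapes the side chain, the other swaps one saturated ring for another without consequence. Every measured compound keeps an amine-bearing side chain, so the outcome of losing it entirely is not anchored by any step here. Given that the step from compound 1 to compound 3 was only modest, a modest rise in this assay is expected rather than a large one. The estimate for compound 4 is 1800 nM, with a range from 500 nM to 7000 nM, an expected step of a 1.5-fold higher number from compound 3 to compound 4 (0.17 log units; within the scatter).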

Compound 4, half-maximal inhibitory concentration: > 10000 nM
Compound 4 was reported as a limit; the forecaster's own chance of this, stated with the estimate: 5%; at least 5.5-fold (0.74 log units) between middle value and limit.
By their numbers in this assay, from the lowest: compounds 3 and 2 (each within the scatter of the next); then compound 1. At a limit, above all of these: compound 4.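

In this assay, compound 4 is reported only as a limit, not as a number: the limit of > 10000 nM in this assay, at which 1 of the 4 values shown sits. Removing the side chain altogether has a clear effect, giving an at least 8.1-fold higher number from compound 3 to compound 4 (0.91 log units; beyond the scatter), an at least 7.5-fold higher number from compound 2 to compound 4 (0.87 log units; beyond the scatter) and an at least 2.5-fold higher number from compound 1 to compound 4 (0.40 log units; beyond the scatter). Among these four compounds, having an amine-bearing side chain on this aromatic carbon therefore counts for more than which ring the amine carries, since the ring swap gave only a 1.1-fold lower number from compound 2 to compound 3 (0.03 log units; within the scatter).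

The compounds shown leave open whether the amine itself matters or simply the presence of a chain at this carbon, which a hydroxymethyl or methoxymethyl group in the same place would help to separate. From the compounds shown here alone, the true size of the loss also stays open, as each of these steps is bounded on one side only.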